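Solubility Outlook When a Pyrrolidine Replaces a Chloropyridine

The compounds below may be only part of what the source reports. "The series", "measured", "known", "first", "only" and "open" are said of these compounds alone.

Going by the values given here, compound 2 `O=C(c1ccc(Cl)nc1)N1CCC(NS(=O)(=O)c2cc(S(=O)(=O)c3ccccc3)ccc2C(F)(F)F)CC1` stands at the top end of the three numbers so far: in a physicochemical assay for solubility (a lower number here means a less soluble compound, a higher number a more soluble compound), compound 2 gives 25000 nM, with compound 3 within the scatter of it and compound 1 beyond. Compound 1 `O=C(c1cccc(Cl)c1)N1CCC(NS(=O)(=O)c2cc(S(=O)(=O)c3ccccc3)ccc2C(F)(F)F)CC1` gives 6300 nM, and compound 3 `CC(C)(C)OC(=O)N1CC[C@@H](C(=O)N2CCC(NS(=O)(=O)c3cc(S(=O)(=O)c4ccccc4)ccc3C(F)(F)F)CC2)C1` gives 12500 nM. The step of a 4.0-fold higher number from compound 1 to compound 2 (0.60 log units; beyond the scatter) lies beyond the scatter, whereas a 2.0-fold lower number from compound 2 to compound 3 (0.30 log units; within the scatter) does not. Compound 4 `O=C([C@H]1CCNC1)N1CCC(NS(=O)(=O)c2cc(S(=O)(=O)c3ccccc3)ccc2C(F)(F)F)CC1` differs from compound 2 in one place: pyrrolidin-3-yl in place of 6-chloropyridin-3-yl on a carbonyl carbon. Among the compounds with values here, no measured step brings in pyrrolidin-3-yl with its hydrogen-bond donor; the nearest is a 2.0-fold lower number from compound 2 to compound 3 (0.30 log units; within the scatter), which puts in 1-(tert-butoxycarbonyl)pyrrolidin-3-yl instead. On that thin basis, compound 4 is expected to come out higher in this assay, by about a 2.0-fold higher number from compound 2 to compound 4 (0.30 log units; within the scatter), with wide uncertainty. The estimate for compound 4 is 50000 nM, within 15000 nM to 200000 nM.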

Compound 4, solubility: 25000 nM
For compound 4 the middle estimate is 2.0-fold (0.30 log units) above the measured one, within the range that was stated.
By their numbers in this assay, from the lowest: compounds 1, 3, 2 and 4 (each within the scatter of the next, the first and the last beyond it).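

In this assay there is no change at the digits printed from compound 2 to compound 4 (within the scatter) when pyrrolidin-3-yl, a non-aromatic ring with a hydrogen-bond donor, replaces 6-chloropyridin-3-yl on this carbonyl carbon, so an aromatic ring is not needed here for a number of this size. Taking off the tert-butoxycarbonyl group gives a 2.0-fold higher number from compound 3 to compound 4 (0.30 log units; within the scatter) and no readable change, while a 4.0-fold higher number from compound 1 to compound 4 (0.60 log units; beyond the scatter) is the only new step beyond the scatter. Nothing measured here explains these numbers. As far as these compounds go, whether an open-chain amine or a carboxylic acid on this carbonyl carbon would move the number beyond the scatter of compound 4 stays open, as does the mirror-image form of pyrrolidin-3-yl.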